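Octyl-phenoxy ketone tetrazoles: liver S9 stability notes

This account rests on a few compounds, and the source may have more. Where it says the series, first, only, none or still open, it means among the compounds named here.

Measured compounds:
compound 1 `CCCCCCCCc1ccc(OCC(=O)Cn2nnc(Cc3ccccc3)n2)cc1`, < 5%
compound 2 `CCCCCCCCc1ccc(OCC(=O)Cn2nnc(C(=O)OC)n2)cc1`, < 5%
compound 3 `CCCCCCCCc1ccc(OCC(=O)Cn2nnnc2Cc2ccccc2)cc1`, 26%

In an ADME assay on S9 fraction from liver (Rattus norvegicus) for metabolic stability, read by LC-MS, using NADPH, with a stated time of 30 min (on this read-out higher numbers stand for a more stable compound and lower numbers for a less stable compound), compound 1 gives < 5%, which is a limit of the assay and not a number. In this assay compound 2 likewise gives < 5%, again a limit. Compound 3 is the only one of the three with a number: in this assay compound 3 gives 26%.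

The change methoxycarbonyl in place of benzyl on an aromatic carbon gives the step that the two limits leave unreadable from compound 1 to compound 2, whose size cannot be read because of the limit of < 5% in this assay, at which 2 of the 3 values shown sit.

Compound 4 `CCCCCCCCc1ccc(OCC(=O)Cn2nnnc2C(=O)OC)cc1` is not yet measured. It differs from compound 3 by methoxycarbonyl in place of benzyl on an aromatic carbon. This is the same kind of change as that from compound 1 to compound 2, but the place is not the same word for word: in compound 4 the entering group sits next to the ring atom that bears a large group, whereas in compound 2 it sits two ring bonds from the ring atom that bears a large group. The cores of compound 1 and compound 3 are made of the same atoms joined differently; the difference between the two cores is not broken down here.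

Among the measured compounds shown here, the only earlier instance of this change, from compound 1 to compound 2, is unreadable in size, so the size of the step that compound 4 will show is uncertain. Compound 3 starts from 26%, which is itself low, and the expected drop is kept moderate for that reason. The step is estimated as a number 12 percentage points lower from compound 3 to compound 4 (beyond the scatter) in this assay. Compound 4 is thus expected to give about 14%, with a range from 3% to 32%.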

Compound 4, percent of the compound remaining: 38%
Compound 4: middle estimate off by 24 percentage points, on the low side; measured number outside the range, above it.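

In this assay, methoxycarbonyl in place of benzyl on an aromatic carbon gives a number 12 percentage points higher from compound 3 to compound 4 (beyond the scatter), so on the core of compound 3 this change does not lower the read-out. With methoxycarbonyl present on both cores, 5-(methoxycarbonyl)-1H-tetrazol-1-yl in place of 5-(methoxycarbonyl)-2H-tetrazol-2-yl gives a number at least 33 percentage points higher from compound 2 to compound 4 (beyond the scatter), which shows that the outcome of the ester depends on the core it sits on, at least for this one pair. Whether the step on the core of compound 3 carries over to the core of compound 1 remains unanswered, because the matching step from benzyl to methoxycarbonyl on that core cannot be read: the limit of < 5% in this assay, at which 2 of the 4 values shown sit.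

The compounds shown leave open whether the higher number of compound 4 belongs to methoxycarbonyl in particular or would also appear with another group at that place, such as a carboxylic acid or a primary amide. They also leave open whether the gap between the two cores persists when the octyl chain gives way to a shorter chain, since all four compounds carry the same octyl chain.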